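A Fluorine Added to the Pendant Phenyl Ring

The compounds below may be only part of what the source reports. "The series", "measured", "known", "first", "only" and "open" are said of these compounds alone.

Two compounds have been measured in a functional assay on HT-29 cells (Homo sapiens) for cytotoxicity, read by MTT assay, with a stated time of 72 h; a higher number here means a weaker inhibitor, a lower number a stronger inhibitor:
- compound 1, `O=C(Nc1ccc(Oc2ccncc2-c2cccnc2)c(F)c1)C1=NN(c2cccc(F)c2)c2ccccc2S1(=O)=O`, gives 430 nM
- compound 2, `Cn1cc(-c2ccccc2)cc(C(=O)Nc2ccc(Oc3ccncc3-c3cccnc3)c(F)c2)c1=O`, gives 7420 nM

Compound 2 has the highest number of the two; its nearest neighbour is compound 1, whose number is lower by a margin beyond the usual scatter. Going by the values given here, the two share the same right-hand portion of the molecule, but the groups attached to the amide differ in more than one place, so no single structural step links them and their values only show how far apart they lie.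

Compound 3, `Cn1cc(-c2ccc(F)cc2)cc(C(=O)Nc2ccc(Oc3ccncc3-c3cccnc3)c(F)c2)c1=O`, has not yet been measured. It differs from compound 2 by fluoro in place of hydrogen on an aromatic carbon, which reads, one bond further out, as phenyl to 4-fluorophenyl. With no measured step of this kind in this set, the expectation is a change within the usual scatter, with no clear direction; the expected step in this assay is a 1.1-fold lower number from compound 2 to compound 3 (0.06 log units; within the scatter). Compound 3 is thus estimated at 6500 nM, within a range from 2500 nM to 17000 nM.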

Compound 3, half-maximal inhibitory concentration: 11200 nM
The estimate for compound 3 lay 1.7-fold (0.24 log units) below the measured number; the measured number falls inside the stated range.
By their numbers in this assay, from the lowest: compound 1; then compounds 2 and 3 (each within the scatter of the next).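

In this assay, going by these compounds alone, putting fluoro in place of hydrogen on the pendant phenyl ring gives a 1.5-fold higher number from compound 2 to compound 3 (0.18 log units; within the scatter) and so provides the one step here that can be read as a single change. Compounds 1 and 2 differ in more than one place and could only show how far apart they lie, whereas this pair shows that going from phenyl to 4-fluorophenyl, with the fluoro para to a large group, does not separate the two compounds in this cell assay. No measurement available here speaks to why the step is this size.

As far as these compounds go, a single small atom at a single place is a narrow test, so it remains open whether a larger or different group there, such as chloro, methoxy or an amine, would also leave the number within the scatter of compound 2. From the compounds shown here alone, it also remains open whether fluoro at another carbon of the same phenyl ring, or the removal of the fluoro on the phenyl ring of compound 1, would give a step of similar size.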